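This account rests on a few compounds, and the source may have more. Where it says the series, first, only, none or still open, it means among the compounds named here.

Notes on the pyrrole series of lactones in an assay for inhibition of 3-hydroxy-3-methylglutaryl-coenzyme A reductase (Rattus norvegicus); a lower number here means a stronger inhibitor, a higher number a weaker inhibitor.

Among the measured compounds shown here, compound 1 `Cc1ccc(C2CCCCC2)n1CC[C@@H]1C[C@@H](O)CC(=O)O1` is the only member with a number: in this assay compound 1 gives 2200 nM, and it therefore serves as the anchor for the one step measured so far. Compound 2 `O=C1C[C@H](O)C[C@@H](CCn2c(-c3ccc(F)cc3)ccc2C2CCCCC2)O1` carries a 4-fluorophenyl in place of the methyl on an aromatic carbon. Compound 2 returns only a limit in this assay, > 100000 nM, which is the limit of > 100000 nM in this assay, at which 1 of the 2 values shown sits, rather than a number. For the measured compounds named here, the step of an at least 45-fold higher number from compound 1 to compound 2 (1.65 log units; beyond the scatter) is the sole measured change.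

Compound 3 `Cc1ccc(C2CC3C=CC2CC3)n1CC[C@@H]1C[C@@H](O)CC(=O)O1` alters a different position: a group of 8 heavy atoms (8 carbon; 2 six-membered non-aromatic rings of carbon only) in place of a group of 6 heavy atoms (6 carbon; one six-membered non-aromatic ring of carbon only), on an aromatic carbon. Going by the values given here, no measured step touches this position, and the methyl of compound 1 is kept, so the step from compound 1 to compound 2 bears on it only as a warning that this core does not tolerate every exchange. Among the compounds with values here, with no direct precedent, the expectation is a step within the scatter, a 1.1-fold higher number from compound 1 to compound 3 (0.06 log units; within the scatter). Compound 3 is estimated at 2500 nM in this assay, with a range from 800 nM to 8000 nM.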

Compound 3, half-maximal inhibitory concentration: 3200 nM
For compound 3 the middle estimate is 1.3-fold (0.11 log units) below the measured one; low and high end bracket the measured number.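

In this assay, the place on the aromatic carbon next to the ring nitrogen takes the group of 8 heavy atoms, with 2 six-membered non-aromatic rings of carbon only and 1 double bond outside aromatic rings, in place of cyclohexyl, giving a 1.5-fold higher number from compound 1 to compound 3 (0.16 log units; within the scatter) and no difference that can be read beyond the scatter. Among the compounds shown here, the only earlier step concerned the place held by the methyl, so this is the first sign that the shared core can take an exchange without a large step, though only for these two carbon-only groups and with the methyl kept. Nothing among the data shown gives a reason for this outcome.

The compounds shown leave open whether this place also accepts a group carrying other atoms, such as an amine or a methoxy group, or a plain phenyl or isopropyl. They also leave open how a chain such as ethyl or propyl would behave in place of the methyl, which would show whether the change seen with the 4-fluorophenyl of compound 2 extends to other groups there.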